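The source may report more compounds than this note shows. Statements on the series, on what has been measured and on what is new or still open speak of the compounds shown alone.

Compound 1 `COc1cc2ncnc(Nc3cccc(C(F)(F)F)c3)c2cc1OCCCN1CCNCCNCCNCC1`, compound 2 `COc1cc2ncnc(Nc3cccc(Cl)c3)c2cc1OCCCN1CCNCCNCCNCC1` and compound 3 `COc1cc2ncnc(Nc3cccc(C(F)(F)F)c3)c2cc1OCCCN1CCNCCNCC1` have been tested in a functional assay on A-431 cells (Homo sapiens) for antiproliferative activity, read by MTT assay, with a stated time of 72 h; on this read-out lower numbers stand for stronger inhibition and higher numbers for weaker inhibition. Compound 1 gives 1950 nM, compound 2 gives 1420 nM and compound 3 gives 1560 nM in this assay. Compound 2 differs from compound 1 by chloro in place of trifluoromethyl on an aromatic carbon, a step of a 1.4-fold lower number from compound 1 to compound 2 (0.14 log units; within the scatter). Compound 3 differs from compound 1 in its core, (a group of 9 heavy atoms (6 carbon, 3 nitrogen; one nine-membered non-aromatic ring with 3 hetero atoms) in place of a group of 12 heavy atoms (8 carbon, 4 nitrogen; one twelve-membered non-aromatic ring with 4 hetero atoms), on a saturated chain carbon, three bonds along the chain from an oxygen on an aromatic ring), with a step of a 1.3-fold lower number from compound 1 to compound 3 (0.10 log units; within the scatter). Compound 4 `COc1cc2ncnc(Nc3cccc(Cl)c3)c2cc1OCCCN1CCNCCNCC1` is not yet measured in this assay; it differs from compound 3 by chloro in place of trifluoromethyl on an aromatic carbon, the same change as that from compound 1 to compound 2, which occurs twice among these compounds. Because the earlier step measured a 1.4-fold lower number from compound 1 to compound 2 (0.14 log units; within the scatter), compound 4 is expected to show a step of a 1.4-fold lower number from compound 3 to compound 4 (0.13 log units; within the scatter), much like the earlier one. The estimate for compound 4 in this assay is 1150 nM, with a range from 600 nM to 2300 nM.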

Compound 4, half-maximal inhibitory concentration: 1130 nM
The estimate for compound 4 lay 1.0-fold (0.01 log units) above the measured number, within the range that was stated.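

In this assay, chloro in place of trifluoromethyl gives a 1.4-fold lower number from compound 3 to compound 4 (0.14 log units; within the scatter), and this matches the same change on the core of compound 1: the same change on two cores in this assay, a 1.4-fold lower number (0.14 log units; within the scatter) from compound 1 to compound 2 and a 1.4-fold lower number (0.14 log units; within the scatter) from compound 3 to compound 4, 1.0-fold (0.00 log units) apart, within the scatter of two such steps
The nine-membered ring in place of the larger ring gives a 1.3-fold lower number from compound 2 to compound 4 (0.10 log units; within the scatter), which likewise matches the earlier step: the same change on two cores in this assay, a 1.3-fold lower number (0.10 log units; within the scatter) from compound 1 to compound 3 and a 1.3-fold lower number (0.10 log units; within the scatter) from compound 2 to compound 4, 1.0-fold (0.00 log units) apart, within the scatter of two such steps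
Both changes thus carry from one core to the other without a difference beyond the scatter, but each step itself lies within the scatter, so this does not show that either change has a real effect of a fixed size.

The compounds shown leave open whether bromo, methoxy or a nitrile in place of chloro would give a step beyond the scatter. They also leave open what a morpholine ring or a longer chain would do.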